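Ring Size on the Amide Carries Over Between Two Cores

The source may hold more compounds than are shown below. What is called first, only, known or untested is meant among the compounds shown, and "the series" means these compounds.

The three measured compounds and their values:

Compound 1, `COc1ccc(N)c(C2=NN(C(=O)C3CCCC3)C(C)(C)S2)c1`, gives 65% in an assay on isolated protein for inhibition of Nitric oxide synthase, inducible (Homo sapiens), read by scintillation counting, with a stated time of 30 min, tested at 50 uM; on this read-out higher numbers stand for more inhibition at the one concentration tested (going by the name of the read-out) and lower numbers for less inhibition.
Compound 2, `COc1ccc(N)c(C2=NN(C(=O)C3CCCCC3)C(C)(C)S2)c1`, gives 100% in this assay.
Compound 3, `CC1(C)SC(c2ccccc2N)=NN1C(=O)C1CCCC1`, gives 42.2% in this assay.

Two changes have been tried so far. The first, (cyclohexyl in place of cyclopentyl on a carbonyl carbon), brings a number 35 percentage points higher from compound 1 to compound 2 (beyond the scatter). The second, (hydrogen in place of methoxy on an aromatic carbon), is the difference between the two cores, and it brings a number 22.8 percentage points lower from compound 1 to compound 3 (beyond the scatter); compound 3 thus stands lowest of the three measured compounds, beyond the scatter from each of the others.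

Compound 4, `CC1(C)SC(c2ccccc2N)=NN1C(=O)C1CCCCC1`, has not yet been measured. It differs from compound 3 by cyclohexyl in place of cyclopentyl on a carbonyl carbon. This is the same change that was made from compound 1 to compound 2, at a place described in the same words: a carbonyl carbon whose other neighbour is an amide-type nitrogen in a ring. The only point on which the two cases differ is the core itself.

Among the measured compounds shown here, with only one earlier example of this change, the expectation rests on it alone. A step of about a number 29.8 percentage points higher from compound 3 to compound 4 (beyond the scatter) is expected from compound 3 to compound 4, somewhat smaller than the earlier one, because a number 35 percentage points higher from compound 1 to compound 2 (beyond the scatter) started from a higher value and ended at the highest of the three measured numbers. Compound 4 is therefore estimated at 72% in this assay, most likely between 55% and 90%.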

Compound 4, a percentage reported as inhibition, at one concentration (the size of the read-out at that concentration, not a potency): 28%
Compound 4: the middle estimate sits 44 percentage points above what was measured; measured number outside the range, below it.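

In this assay, cyclohexyl in place of cyclopentyl on a carbonyl carbon gives a number 14.2 percentage points lower from compound 3 to compound 4 (beyond the scatter), so the same change points the opposite way once the core is different: the same change on two cores in this assay, a number 35 percentage points higher (beyond the scatter) from compound 1 to compound 2 and a number 14.2 percentage points lower (beyond the scatter) from compound 3 to compound 4, 49.2 percentage points apart, beyond the scatter of two such steps

Read the other way round, hydrogen in place of methoxy on an aromatic carbon gives a number 72 percentage points lower from compound 2 to compound 4 (beyond the scatter), a much larger drop than the one seen with cyclopentyl on the carbonyl: the same change on two cores in this assay, a number 22.8 percentage points lower (beyond the scatter) from compound 1 to compound 3 and a number 72 percentage points lower (beyond the scatter) from compound 2 to compound 4, 49.2 percentage points apart, beyond the scatter of two such steps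

The two changes therefore do not add up independently in these four compounds, and a step measured on one core cannot simply be copied to the other, but the data do not show why this happens or whether it holds for any other pair of groups.

From the compounds shown here alone, it remains open whether the reversal follows ring size in a steady way, which a smaller ring such as cyclobutyl, an open chain such as pentyl, or a cyclohexyl ring carrying an amine could test on both cores. Going by these compounds, it is also open whether another group in place of the methoxy, such as ethoxy or fluorine, would behave like methoxy or like hydrogen with each of the two rings.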